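One More Methoxy on Compound 2

The source may hold more compounds than are shown below. What is called first, only, known or untested is meant among the compounds shown, and "the series" means these compounds.

In a functional assay on the whole organism (strain Kunming) with Mus musculus as the target, with a stated time of 0.5 h (on this read-out lower numbers stand for an effect already at smaller amounts and higher numbers for an effect only at larger amounts of compound), compound 1 `COc1ccccc1/C=C/C(=O)OC/C=C/c1cc(OC)c(OC)cc1OC` gives 240 mg/kg and compound 2 `COc1cc(OC)c(OC)cc1/C=C/COC(=O)/C=C/c1ccc(OC)c(OC)c1` gives 173 mg/kg. These two numbers do not separate, since the measured change is a 1.4-fold lower number from compound 1 to compound 2 (0.14 log units; within the scatter). Compound 3 `COc1cc(OC)c(OC)cc1/C=C/COC(=O)/C=C/c1ccccc1C(F)(F)F` reaches only a limit, > 200 mg/kg. Compound 2 therefore has no clear lead over either neighbour, and the remaining change reads an at least 1.1-fold higher number from compound 2 to compound 3 (0.06 log units; that floor lies within the scatter).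

Compound 4 `COc1cc(OC)c(OC)cc1/C=C/COC(=O)/C=C/c1ccc(OC)c(OC)c1OC` carries one change from compound 2: methoxy in place of hydrogen on an aromatic carbon. Going by the values given here, the closest precedent is the change in methoxy groups on that ring, a 1.4-fold lower number from compound 1 to compound 2 (0.14 log units; within the scatter), so no shift beyond the scatter is expected in this assay. The expected change is a 1.0-fold higher number from compound 2 to compound 4 (0.02 log units; within the scatter). For compound 4 the estimated value is 180 mg/kg, with an expected range of 90 mg/kg to 350 mg/kg.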

Compound 4, dose for half-maximal effect: 203 mg/kg
For compound 4 the middle estimate is 1.1-fold (0.05 log units) below the measured one; the range from low to high includes it.
By their numbers in this assay, from the lowest: compounds 2, 4 and 1 (each within the scatter of the next).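

Adding methoxy in place of hydrogen on this aromatic carbon, ortho to a large group and to a methoxy group, gives a 1.2-fold higher number from compound 2 to compound 4 (0.07 log units; within the scatter) in this assay. Going by these compounds alone, this carbon therefore takes one added methoxy with no readable shift, a single-group result that the earlier steps did not give, as they exchanged a whole substituted phenyl group or ended at a limit. Compound 3 gives only a limit, and the steps that depend on it cannot be read: the limit of > 200 mg/kg in this assay, at which 1 of the 4 values shown sits.

From the compounds shown here alone, whether an amine, a carboxylic acid or a longer chain such as ethoxy on this same carbon would move the number beyond the scatter remains open.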